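A few compounds are considered here, and "the series" means these few. Any claim that something is new, unique, unknown or untested is made for them only; others in the source may bear on it.

Measured compounds:
- compound 1 `O=c1ccc2cc(OCc3cc(-c4ccccc4Cl)no3)ccc2o1`: in a functional assay on COLO 205 cells (Homo sapiens) for cytotoxicity, read by MTT assay, with a stated time of 48 h (a lower number here means a stronger inhibitor, a higher number a weaker inhibitor), compound 1 carries the entry "not determined" (no result reported)
- compound 2 `O=c1ccc2cc(OCc3cc(-c4ccccc4)no3)ccc2o1`: in this assay compound 2 carries the entry "not determined" (no result reported)
- compound 3 `O=c1ccc2cc(OCc3cc(-c4ccc5ccccc5c4)no3)ccc2o1`: in this assay compound 3 gives 48700 nM

Compound 1 stands on no number in this assay; a second member of the series, compound 2, is likewise without a result. The only figure available on the shared core comes from compound 3, and that figure places compound 3 among weak inhibitors in this assay.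

Compound 4 `O=c1ccc2cc(OCc3cc(-c4cccc(Cl)c4)no3)ccc2o1` is reached from compound 1 by one change: 3-chlorophenyl in place of 2-chlorophenyl on an aromatic carbon. Among the compounds with values here, no step between two measured compounds is available to calibrate this change, and compound 1 itself has no value to step from, so the size of the step in this assay cannot be derived from the series. With a single weak number on the core, the expectation is that moving the chlorine from the 2-position to the 3-position of the phenyl ring gives no step beyond the usual scatter, and that compound 4 lands in the same weak range as compound 3.

Compound 4 is therefore expected to give about 40000 nM in this assay, within a range of 10000 nM to 150000 nM.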

Compound 4, half-maximal inhibitory concentration: 32500 nM
Beside the measured number, compound 4's estimate is 1.2-fold (0.09 log units) above it, within the range that was stated.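

In this assay, within the data shown here, compound 4 gives 32500 nM, but compound 1 offers no single number to step from, so no step can be read between compound 1 and compound 4. The compounds shown leave open whether the chlorine's position on the phenyl ring matters in this assay. No supporting evidence bears on this result.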